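The source may report more compounds than this note shows. Statements on the series, on what has been measured and on what is new or still open speak of the compounds shown alone.

Compound 1: `COCCCN1CCC(O)(CNC(=O)c2nc(C(C)C)n3ccccc23)CC1` — 41%
Compound 2: `CC(C)c1nc(C(=O)NCC2(O)CCN(CC(C)(C)O)CC2)c2ccccn12` — 41%
Compound 3: `CC(C)c1nc(-c2nnc(C3CCN(CC4CCC4)CC3)o2)c2ccccn12` — 63%

Of the compounds shown here, three have been measured in a functional assay on CHO cells for agonist activity at 5-hydroxytryptamine receptor 4 (Homo sapiens), read by a luciferase reporter and cAMP accumulation, with a stated time of 4 h; a higher number here means a larger maximal response, a lower number a smaller maximal response. Compound 3 stands highest of the three: its value is beyond the scatter above both compound 1 and compound 2, which sit within the scatter of each other. Compound 4, `COCCCN1CCC(c2nnc(-c3nc(C(C)C)n4ccccc34)o2)CC1`, has not yet been measured in this assay. It differs from compound 3 in one place: 2-methoxyethyl in place of cyclobutyl on a saturated chain carbon bound to an amine nitrogen in a ring.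

Within the data shown here, only one measured step touches the same place. There, from compound 1 to compound 2, the change no change at the digits printed from compound 1 to compound 2 (within the scatter). That step swaps one chain for another on the saturated chain carbon bound to the amine nitrogen in the ring, and it left the maximal response where it was. Compound 3 and compound 4 share a different core from compound 1 and compound 2, so the parallel is loose, and the measured step does not involve a cyclobutyl leaving. On this basis the expectation for compound 4 is a step of a number 5 percentage points lower from compound 3 to compound 4 (within the scatter), that is, no change beyond the scatter. Compound 4 is therefore estimated at 58%, with a range from 42% to 74%.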

Compound 4, largest response reached (Emax), in percent of the reference or control that the assay uses: 67%
Compound 4: the middle estimate sits 9 percentage points below what was measured; low and high end bracket the measured number.
By their numbers in this assay, from the lowest: compounds 1 and 2 (each within the scatter of the next); then compounds 3 and 4 (each within the scatter of the next).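

In this assay, putting 2-methoxyethyl in place of cyclobutyl on a saturated chain carbon bound to an amine nitrogen in a ring gives a number 4 percentage points higher from compound 3 to compound 4 (within the scatter) and so shows that, on the shared core of these two compounds, the cyclobutyl ring can give way to an open chain with one hydrogen-bond acceptor without a change beyond the scatter. Together with no change at the digits printed from compound 1 to compound 2 (within the scatter) on the other core, this makes two steps at this position, and neither moves the maximal response beyond the scatter. Nothing shown here gives a reason why the response holds at this position.

Going by these compounds, whether this tolerance extends to a chain ending in an amine or a carboxylic acid remains open. So does the effect of a longer chain at this position.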